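The source may report more compounds than this note shows. Statements on the series, on what has been measured and on what is new or still open speak of the compounds shown alone.

Compound 3 `O=C(Nc1ccccc1)c1csc(-c2c[nH]c3ccccc23)n1` was examined in a functional assay on MDA-MB-231 cells (Homo sapiens) for cytotoxicity, read by MTT assay, with a stated time of 48 h, in the presence of a further agent that is not named here; a lower number here means a stronger inhibitor, a higher number a weaker inhibitor. In this assay compound 3 gives > 100000 nM, which is a limit of the assay and not a number. Two neighbours on the shared core were measured beside it. Compound 1 `O=C(NCc1ccccc1)c1csc(-c2c[nH]c3ccccc23)n1` in this assay gives > 100000 nM, again a limit. Compound 2 `O=C(Nc1ccccc1)c1csc(-c2cn(Cc3ccc(Cl)cc3)c3ccccc23)n1` in this assay gives > 100000 nM, also a limit. The step that the two limits leave unreadable from compound 1 to compound 3, a phenyl in place of benzyl on an amide-type nitrogen, cannot be sized because the limit of > 100000 nM in this assay, at which 3 of the 3 values shown sit, covers both ends of it. The same holds for a step that the two limits leave unreadable from compound 2 to compound 3, hydrogen in place of 4-chlorobenzyl on an aromatic nitrogen, because the limit of > 100000 nM in this assay, at which 3 of the 3 values shown sit, hides whatever change there was. Compound 3 therefore stands at the limit together with the other two, with no readable step to set it apart.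

Compound 4 `Cc1ccc(NC(=O)c2csc(-c3c[nH]c4ccccc34)n2)cc1` differs from compound 3 by methyl in place of hydrogen on an aromatic carbon, the methyl entering on an aromatic carbon of a six-membered aromatic ring of carbon only, para to a large group. Within the data shown here, no measured step bears directly on this change, and the two steps that exist are unreadable. Compound 4 is therefore expected to remain in the same region, with a step of a number no higher from compound 3 to compound 4 (the limit leaves the size open) expected to be no larger than the scatter. Compound 4 is estimated at 100000 nM, between 30000 nM and 300000 nM, and is most likely again reported as a limit.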

Compound 4, half-maximal inhibitory concentration: > 100000 nM
Compound 4: only a limit was reported (the forecaster's own chance of this, stated with the estimate: 85%); the middle value sits exactly at the limit.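

In this assay compound 4 gives > 100000 nM, which is a limit and not a number. The steps from compound 3 to compound 4 and from compound 1 to compound 4 cannot be read, because both ends of each share one limit: the limit of > 100000 nM in this assay, at which 4 of the 4 values shown sit.

The compounds shown leave open whether any change on the shared core alters the read-out.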